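Homologating the ring amine in the sulfonyl series

This account rests on a few compounds, and the source may have more. Where it says the series, first, only, none or still open, it means among the compounds named here.

Measured compounds in a functional assay on HEK293 cells for inhibition of 5-hydroxytryptamine receptor 6 (Homo sapiens), read by cAMP accumulation; on this read-out higher numbers stand for weaker inhibition and lower numbers for stronger inhibition:
compound 1, `CNc1nn2c(C)cc(C)nc2c1S(=O)(=O)c1ccccc1`, 0.263 nM; 0.26 nM (2 entries)
compound 2, `CNc1nn2c(C)c(NC(C)=O)c(C)nc2c1S(=O)(=O)c1ccccc1`, 4.68 nM
compound 3, `CNc1nn2c(C)c(N(C)C)c(C)nc2c1S(=O)(=O)c1ccccc1`, 0.209 nM
Not yet measured: compound 4, `CNc1nn2c(C)c(CN(C)C)c(C)nc2c1S(=O)(=O)c1ccccc1`.

Compound 3 holds the lowest of the two single numbers in this assay; its nearest neighbour is compound 2, with the step of a 22-fold lower number from compound 2 to compound 3 (1.35 log units; beyond the scatter). Compound 1, which carries no substituent at that position, is known from repeated runs, (the several entries of compound 1 in this assay, 0.263 nM; 0.26 nM (2 entries)), and its value sits close to that of compound 3.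

The step to compound 4 is (dimethylamino)methyl in place of dimethylamino on an aromatic carbon. Among the compounds with values here, the only measured step at this position, a 22-fold lower number from compound 2 to compound 3 (1.35 log units; beyond the scatter), exchanges one substituent class for another and is large; it does not directly address inserting a methylene between the ring and the amine. Since compound 1 and compound 3 lie close together in this assay, this position tolerates both hydrogen and dimethylamino, so a modest step or none beyond the scatter is expected for a 1.9-fold higher number from compound 3 to compound 4 (0.28 log units; within the scatter). Compound 4 is estimated at 0.4 nM, within 0.1 nM to 1.6 nM.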

Compound 4, inhibition constant: 0.708 nM
Compound 4: middle estimate off by 1.8-fold (0.25 log units), on the low side; measured number inside the range.
By their numbers in this assay, from the lowest: compound 3; then compound 4; then compound 2.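

In this assay, inserting a methylene while keeping the dimethylamino group gives a 3.4-fold higher number from compound 3 to compound 4 (0.53 log units; beyond the scatter), so the number at this position responds to where the amine sits and not only to whether an amine is present. The (dimethylamino)methyl group also keeps a clear margin over acetamido, with a 6.6-fold lower number from compound 2 to compound 4 (0.82 log units; beyond the scatter), leaving compound 2 with the highest number of the three. Compound 1, with hydrogen at this position, remains the reference for both amines, and its repeat entries agree closely: the several entries of compound 1 in this assay, 0.263 nM; 0.26 nM (2 entries)

On these data alone, whether a longer chain such as (dimethylamino)ethyl would raise the number further remains open. It is also unclear whether the amine nitrogen is needed at all, which a cyclic amine such as morpholine or an all-carbon group such as isopropyl at this position would help to settle.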